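From 3,4-dihydroxyphenyl to 2,5-dihydroxyphenyl

The compounds below may be only part of what the source reports. "The series", "measured", "known", "first", "only" and "open" are said of these compounds alone.

Of the compounds shown here, two have been measured so far in a functional assay (Mus musculus) for inhibition, with a stated time of 5 days; on this read-out lower numbers stand for stronger inhibition and higher numbers for weaker inhibition. Compound 1 `O=C(O)/C=C/c1cn(-c2ccc(O)cc2)nc1-c1ccc(O)cc1` gives > 100000 nM, which is a limit of the assay and not a number. Compound 2 `O=C(O)/C=C/c1cn(-c2ccc(O)cc2)nc1-c1ccc(O)c(O)c1` gives > 100000 nM, which is likewise a limit. Compound 2 therefore has no exact position, and the pair shares one reading: the limit of > 100000 nM in this assay, at which 2 of the 2 values shown sit.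

Within the data shown here, the only measured step, a step that the two limits leave unreadable from compound 1 to compound 2, places a hydroxy in place of hydrogen on an aromatic carbon. Its size cannot be read, so it offers only weak guidance.

Compound 3 `O=C(O)/C=C/c1cn(-c2ccc(O)cc2)nc1-c1cc(O)ccc1O` has the same atoms as compound 2, joined differently: 2,5-dihydroxyphenyl in place of 3,4-dihydroxyphenyl on an aromatic carbon. A 2,5-dihydroxyphenyl stands in place of the 3,4-dihydroxyphenyl on an aromatic carbon. Among the measured compounds shown here, no measured step tests this kind of exchange, so the data favour neither direction. The most likely outcome is another reading at the limit in this assay.

The expected change, a number no higher from compound 2 to compound 3 (the limit leaves the size open), is therefore no readable step in either direction. Compound 3 is estimated at 100000 nM, with an expected range of 30000 nM to 300000 nM.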

Compound 3, half-maximal inhibitory concentration: > 100000 nM
Compound 3 was reported as a limit; the forecaster's own chance of this, stated with the estimate: 75%; the middle value sits exactly at the limit.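

Among these compounds, compound 3 is also reported as a limit and not a number, so no step among compound 1, compound 2 and compound 3 can be read. All three share a single reading: the limit of > 100000 nM in this assay, at which 3 of the 3 values shown sit.

In this assay the compounds shown leave open how strongly any of them inhibits, and whether the placing of the hydroxy groups makes any difference.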